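This account rests on a few compounds, and the source may have more. Where it says the series, first, only, none or still open, it means among the compounds named here.

Measured so far in a functional assay on HT cells (Homo sapiens) for antiproliferative activity, read by fluorescence, with a stated time of 72 h; a lower number here means a stronger inhibitor of growth, a higher number a weaker inhibitor of growth:

compound 1 `CC(C)c1n[nH]c2c(NCc3ccc(-c4ccccn4)cc3)nc(SCC(N)CN)nc12`: 480 nM
compound 2 `CC(C)c1n[nH]c2c(NCc3ccc(-c4ccccn4)cc3)nc(SCC(C)(C)O)nc12`: 507 nM
compound 3 `CSc1nc(NCc2ccc(-c3ccccn3)cc2)c2[nH]nc(C(C)C)c2n1`: 783 nM

Compound 3 stands within the scatter of both other compounds. Compound 4 (`CC(C)c1n[nH]c2c(NCc3ccc(-c4ccccn4)cc3)nc(SCCN)nc12`) carries aminomethyl in place of hydrogen on a saturated chain carbon bound to a sulfur. Going by the values given here, two measured steps bear on this change, and both lie within the scatter: 1,2-diaminoethyl gives way to hydrogen (a 1.6-fold higher number from compound 1 to compound 3 (0.21 log units; within the scatter)), and 1-hydroxy-1-methylethyl gives way to hydrogen (a 1.5-fold higher number from compound 2 to compound 3 (0.19 log units; within the scatter)). The first is the closer comparison, since compound 1 also has an amino-bearing chain. No change beyond the scatter is therefore expected in this assay, and the expected 1.4-fold lower number from compound 3 to compound 4 (0.15 log units; within the scatter) is small. Compound 4 is estimated at 550 nM (expected range 300 nM to 1000 nM).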

Compound 4, concentration for 50% growth inhibition: 22 nM
Beside the measured number, compound 4's estimate is 25-fold (1.40 log units) above it; measured number below the stated range.
By their numbers in this assay, from the lowest: compound 4; then compounds 1, 2 and 3 (each within the scatter of the next).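

In this assay, going by these compounds alone, the change from methylsulfanyl to (2-aminoethyl)sulfanyl gives a 36-fold lower number from compound 3 to compound 4 (1.55 log units; beyond the scatter) and passes well beyond the scatter, whereas the steps among the earlier compounds all stayed within it. An amine on the chain is not enough in itself: hydrogen in place of aminomethyl brings a 22-fold lower number from compound 1 to compound 4 (1.34 log units; beyond the scatter) and aminomethyl in place of 1-hydroxy-1-methylethyl brings a 23-fold lower number from compound 2 to compound 4 (1.36 log units; beyond the scatter) so the number depends on the exact chain at this position. Nothing available explains this sharp response. Still open, as far as these compounds go, is whether a longer chain ending in an amine keeps the low number. From the compounds shown here alone, a dimethylamine or a carboxylic acid at the chain end also remains untested here.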